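Trading a methylphenyl for a dichlorophenyl on the carbonyl

A few compounds are considered here, and "the series" means these few. Any claim that something is new, unique, unknown or untested is made for them only; others in the source may bear on it.

The set shares one core, seen in compound 1 `Cc1cccc(C(=O)N(C(=S)OCCN2C(=O)c3ccccc3C2=O)c2ccc(Cl)cc2)c1`, compound 2 `Cc1ccc(N(C(=O)c2cccc(C)c2)C(=S)OCCN2C(=O)c3ccccc3C2=O)cc1` and compound 3 `O=C1c2ccccc2C(=O)N1CCOC(=S)N(C(=O)c1ccc(Cl)c(Cl)c1)c1ccc(Cl)cc1`, and in the not yet measured compound 4 `Cc1ccc(N(C(=O)c2c(Cl)cccc2Cl)C(=S)OCCN2C(=O)c3ccccc3C2=O)cc1`. In an ADME assay on MT4 cells (Homo sapiens) for cytotoxicity, read by MTT assay (on this read-out higher numbers stand for lower toxicity in this test and lower numbers for higher toxicity in this test), compound 1 gives 58000 nM. Compound 2 reaches only the limit of this assay, > 100000 nM, so no number is known for it. Compound 2 thus stands at the limit of > 100000 nM in this assay, at which 1 of the 3 values shown sits. Compound 3 gives 35000 nM in this assay.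

Two measured steps frame the question. an at least 1.7-fold higher number from compound 1 to compound 2 (0.23 log units; that floor lies within the scatter). a 1.7-fold lower number from compound 1 to compound 3 (0.22 log units; within the scatter). The change from compound 2 to compound 4 is 2,6-dichlorophenyl in place of 3-methylphenyl on a carbonyl carbon. The step from compound 1 to compound 3 likewise exchanges the 3-methylphenyl on the carbonyl carbon for a dichlorophenyl and stays within the scatter, so no step beyond the scatter is anticipated here either. The expected step is a number no higher from compound 2 to compound 4 (the limit leaves the size open). Compound 4 is estimated at 100000 nM in this assay, with a range from 45000 nM to 220000 nM, and a second report of only a limit rather than a number is quite likely.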

Compound 4, half-maximal cytotoxic concentration: 22000 nM
The estimate for compound 4 lay 4.5-fold (0.66 log units) above the measured number; measured number outside the range, below it.
By their numbers in this assay, from the lowest: compounds 4, 3 and 1 (each within the scatter of the next, the first and the last beyond it). At a limit, above all of these: compound 2.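

In this assay, the change on the carbonyl carbon from 3-methylphenyl to 2,6-dichlorophenyl gives an at least 4.5-fold lower number from compound 2 to compound 4 (0.65 log units; beyond the scatter). This shows that a change at this position can move the read-out towards higher toxicity in this test by more than the scatter, which the earlier exchange for 3,4-dichlorophenyl, a 1.7-fold lower number from compound 1 to compound 3 (0.22 log units; within the scatter), did not show. The true size of the new step is unknown, since compound 2 has only a limit: the limit of > 100000 nM in this assay, at which 1 of the 4 values shown sits.

The two exchanges differ both in the dichlorophenyl group that enters and in the aromatic group on the nitrogen, where one compound pair carries chloro and the other methyl, so the compounds shown do not separate these two differences. On these data alone, how a plain phenyl, a 2,6-difluorophenyl or a 2,6-dimethylphenyl on the same carbonyl carbon would read in this assay remains open, and with it whether chlorine itself matters in this change.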